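The source may hold more compounds than are shown below. What is called first, only, known or untested is meant among the compounds shown, and "the series" means these compounds.

Working notes on the series. Compound 1 `CC(=O)OC(C)n1cnc2c(Cl)nc(N)nc21` and compound 2 `CC(=O)OCCOn1cnc2c(Cl)nc(N)nc21` share the same heterocyclic core but carry different chains on the ring nitrogen; the difference between the two cores is not broken down here. Compound 3 `CC(=O)OC(C)n1cnc2c(S)nc(N)nc21` comes from compound 1 by sulfanyl in place of chloro on an aromatic carbon and compound 4 `CC(=O)OCCOn1cnc2c(S)nc(N)nc21` from compound 2 by sulfanyl in place of chloro on an aromatic carbon. The surroundings of the changed carbon read the same in both pairs, so this is the same change made twice within the series.

In a functional assay on CCRF-CEM cells (Homo sapiens) for inhibition (a higher number here means a weaker inhibitor, a lower number a stronger inhibitor), compound 1 reaches only a limit of the assay, > 500000 nM. Compound 2 likewise reaches only a limit of the assay, > 500000 nM. Compound 3 gives a measured number in this assay, 381000 nM. The step of an at least 1.3-fold lower number from compound 1 to compound 3 (0.11 log units; that floor lies within the scatter) can therefore be stated only as a floor, and that floor rests on (the limit of > 500000 nM in this assay, at which 2 of the 3 values shown sit); whether the true step is larger than the scatter cannot be told from the data in hand.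

For compound 4 the same change is expected to give a step of about an at least 1.2-fold lower number from compound 2 to compound 4 (0.09 log units; that floor lies within the scatter), since the same change within the series gave the step of an at least 1.3-fold lower number from compound 1 to compound 3 (0.11 log units; that floor lies within the scatter). Compound 4 is expected in this assay at around 400000 nM, within a range from 150000 nM to 1500000 nM, with a fair chance that the assay again returns only a limit for compound 4.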

Compound 4, half-maximal inhibitory concentration: 7500 nM
For compound 4 the middle estimate is 53-fold (1.73 log units) above the measured one, outside the stated range (below it).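

In this assay, sulfanyl in place of chloro on an aromatic carbon gives a large step on the core of compound 2, an at least 66-fold lower number from compound 2 to compound 4 (1.82 log units; beyond the scatter), so on this core the change clearly carries weight. On the core of compound 1 the same change gives only a floor that stays within the scatter, an at least 1.3-fold lower number from compound 1 to compound 3 (0.11 log units; that floor lies within the scatter), and setting the two side by side leaves the comparison unsettled: the same change on two cores in this assay, an at least 1.3-fold lower number (0.11 log units; that floor lies within the scatter) from compound 1 to compound 3 and an at least 66-fold lower number (1.82 log units; beyond the scatter) from compound 2 to compound 4; the limit leaves it open whether they differ This shows that the large step can occur in the series, but it does not show that its size carries over from one core to the other or that the two cores respond differently, because both steps start from a limit rather than a number: the limit of > 500000 nM in this assay, at which 2 of the 4 values shown sit.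

The compounds shown leave open whether the large step on the core of compound 2 is particular to sulfanyl or would also appear with an amine or a methylsulfanyl group on the same carbon. They also leave open how the step would behave on a core with a longer chain on the ring nitrogen, or with a free hydroxyl in place of the acetate ester.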